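Swapping a sulfur-linked chlorophenyl for an oxygen-linked one

The source may hold more compounds than are shown below. What is called first, only, known or untested is meant among the compounds shown, and "the series" means these compounds.

Three compounds share a core carrying a methylsulfonyl group and an acylguanidine, and differ only in one group. In a functional assay for inhibition of sodium/hydrogen exchanger (Oryctolagus cuniculus) (a higher number here means a weaker inhibitor, a lower number a stronger inhibitor), compound 1 `Cc1cc(F)c(S(C)(=O)=O)cc1C(=O)N=C(N)N` gives 44 nM, compound 2 `CCCCCc1cc(C)c(C(=O)N=C(N)N)cc1S(C)(=O)=O` gives 27 nM, and compound 3 `Cc1cc(Sc2ccc(Cl)cc2)c(S(C)(=O)=O)cc1C(=O)N=C(N)N` gives 19 nM. Compound 3 sits at the low end: a 2.3-fold lower number from compound 1 to compound 3 (0.36 log units; beyond the scatter), while a 1.4-fold lower number from compound 2 to compound 3 (0.15 log units; within the scatter).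

Compound 4 `Cc1cc(Oc2cccc(Cl)c2)c(S(C)(=O)=O)cc1C(=O)N=C(N)N` differs from compound 3 by 3-chlorophenoxy in place of (4-chlorophenyl)sulfanyl on an aromatic carbon. For the measured compounds named here, no measured step exchanges sulfur for oxygen in this linker or moves the chlorine on the outer ring, so the bearing of earlier steps is indirect; the modest step from compound 1 and the flat step from compound 2 suggest a large aromatic group here gives similar numbers. A change within the scatter is therefore expected, a 1.3-fold higher number from compound 3 to compound 4 (0.12 log units; within the scatter). Compound 4 is estimated at 25 nM, with a range from 10 nM to 65 nM.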

Compound 4, half-maximal inhibitory concentration: 21 nM
Compound 4: the middle estimate sits 1.2-fold (0.08 log units) above what was measured; low and high end bracket the measured number.
By their numbers in this assay, from the lowest: compounds 3, 4, 2 and 1 (each within the scatter of the next, the first and the last beyond it).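

In this assay, oxygen for sulfur in the linker and a different chlorine place on the outer ring, taken together, leave the number flat, with a 1.1-fold higher number from compound 3 to compound 4 (0.04 log units; within the scatter), so this position takes either chlorinated aromatic group alike. Compound 4 also repeats the picture set by compound 3, with a 1.3-fold lower number from compound 2 to compound 4 (0.11 log units; within the scatter) against pentyl and a 2.1-fold lower number from compound 1 to compound 4 (0.32 log units; beyond the scatter) against fluoro. Nothing available explains why these two groups read alike.

From the compounds shown here alone, the separate contributions of the linking atom and the chlorine place remain open. So does the outcome with an amine or a carboxylic acid at this position.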